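A few compounds are considered here, and "the series" means these few. Any claim that something is new, unique, unknown or untested is made for them only; others in the source may bear on it.

Measured so far:
compound 1 `COc1ccc(C2=NN(c3ccc(-c4ccccc4)nn3)C(c3ccc(F)cc3)C2)cc1`, 9160 nM
compound 2 `COc1ccc(C2=NN(c3ccc(-c4ccccc4)nn3)C(c3ccc(C(F)(F)F)cc3)C2)cc1`, > 100000 nM

In a functional assay on HepG2 cells (Homo sapiens) for antiproliferative activity, read by MTT assay, with a stated time of 24 h (on this read-out higher numbers stand for weaker inhibition and lower numbers for stronger inhibition), compound 1 gives 9160 nM. For compound 2 this assay reports only a limit, > 100000 nM. Going by the values given here, the one measured step, an at least 10-fold higher number from compound 1 to compound 2 (1.03 log units; beyond the scatter), sits at the limit of > 100000 nM in this assay, at which 1 of the 2 values shown sits, so its true size is not known. Compound 3 `COc1ccc(C2=NN(c3ccc(-c4ccccc4)nn3)C(c3ccc(OC)cc3OC)C2)cc1` carries 2,4-dimethoxyphenyl in place of 4-(trifluoromethyl)phenyl on a saturated ring carbon. Among the compounds with values here, no measured step covers this change; the only related step is the one from compound 1 to compound 2. Compound 3 is expected to fall between the two measured compounds, estimated at 25000 nM (range 6000 nM to 100000 nM), an expected step of an at least 4.0-fold lower number from compound 2 to compound 3 (0.60 log units; beyond the scatter), with a fair chance of another limit.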

Compound 3, half-maximal inhibitory concentration: > 100000 nM
Compound 3: no number, only a limit; the forecaster's own chance of this, stated with the estimate: 35%; middle value at least 4.0-fold (0.60 log units) away from the limit.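

In this assay, compound 3 gives only a limit, > 100000 nM. On the saturated ring carbon, 2,4-dimethoxyphenyl in place of 4-fluorophenyl gives an at least 10-fold higher number from compound 1 to compound 3 (1.03 log units; beyond the scatter), so a second, different replacement of 4-fluorophenyl at this position also leaves no measurable number, and the step from compound 2 to compound 3 cannot be read. Compound 2 and compound 3 therefore cannot be ranked against each other: the limit of > 100000 nM in this assay, at which 2 of the 3 values shown sit.

As far as these compounds go, whether a 4-chlorophenyl, 4-aminophenyl or unsubstituted phenyl group at this position would give a readable number stays open. From the compounds shown here alone, how far the true values of compound 2 and compound 3 lie beyond the limit also stays open.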